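Cathepsin D inhibitors: carbamate trimming at the valine terminus

The source may report more compounds than this note shows. Statements on the series, on what has been measured and on what is new or still open speak of the compounds shown alone.

Measured compounds:
- compound 1 `CC(C)CCNC(=O)[C@H](C)NC(=O)C[C@H](C)[C@@H](CC(C)C)NC(=O)[C@@H](NC(=O)[C@@H](NC(=O)OC(C)(C)C)C(C)C)C(C)C`: 31 nM; 47 nM (2 entries)
- compound 2 `COC(=O)[C@H](C)NC(=O)C[C@H](O)[C@H](CC(C)C)NC(=O)[C@@H](NC(=O)[C@@H](NC(=O)CC(C)C)C(C)C)C(C)C`: 90 nM
- compound 3 `CC(C)CCNC(=O)[C@H](C)NC(=O)C[C@H](O)[C@H](CC(C)C)NC(=O)[C@@H](NC(=O)OC(C)(C)C)C(C)C`: 2700 nM

In an assay on isolated protein for inhibition of cathepsin D (Bos taurus) (a higher number here means a weaker inhibitor, a lower number a stronger inhibitor), compound 1 gives 31 nM; 47 nM (2 entries), with the several entries of compound 1 in this assay, 31 nM; 47 nM (2 entries) showing agreement between its repeat entries. Compound 2 gives 90 nM. Compound 3 gives 2700 nM, the highest of the single numbers shown; its gap to compound 2 lies beyond the scatter, though the two differ in more than one place and no single step connects them.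

Compound 4 `CC(C)CCNC(=O)[C@H](C)NC(=O)C[C@H](O)[C@H](CC(C)C)NC(=O)[C@@H](NC(=O)OC(C)C)C(C)C` is not yet measured. It differs from compound 3 by hydrogen in place of methyl on a saturated chain carbon bound to an oxygen next to a carbonyl group and two saturated chain carbons. With no measured step of this kind in the series, the change is expected to move this assay little, if at all, beyond the scatter.

The estimate for compound 4 is 3500 nM, within 1200 nM to 10000 nM, corresponding to a 1.3-fold higher number from compound 3 to compound 4 (0.11 log units; within the scatter) as an expected step.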

Compound 4, inhibition constant: 620 nM
Compound 4: middle estimate off by 5.6-fold (0.75 log units), on the high side; the whole stated range lies above it.
By their numbers in this assay, from the lowest: compound 2; then compound 4; then compound 3.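

Trimming one methyl from tert-butoxycarbonyl to isopropoxycarbonyl is not a neutral change at this carbon: in this assay it gives a 4.4-fold lower number from compound 3 to compound 4 (0.64 log units; beyond the scatter). The end of this carbamate therefore affects the read-out, and of the two groups compared in this single step, isopropoxycarbonyl gives the lower number. Repeat entries in the series stay close, which supports reading the step at face value: the several entries of compound 1 in this assay, 31 nM; 47 nM (2 entries)

From the compounds shown here alone, whether the gain continues to ethoxycarbonyl or methoxycarbonyl, or how a longer chain such as n-butoxycarbonyl behaves, stays open. Also open, going by these compounds, is whether the same change holds on compound 1, which carries tert-butoxycarbonyl too.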